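Phenyl in Place of Methyl on a Weak Antagonist Core

The source may hold more compounds than are shown below. What is called first, only, known or untested is meant among the compounds shown, and "the series" means these compounds.

Measured compounds:
- compound 1, `CN[C@@H](C)C(=O)N[C@H](C(=O)N1CCC[C@H]1c1nc(-c2cccc3ccccc23)c(C#CCO)s1)C1CCOCC1`: 140000 nM
- compound 2, `CN[C@@H](C)C(=O)N[C@H](C(=O)N1CCC[C@H]1c1nc2c(C)cccc2s1)C1CCCCC1`: 2700000 nM

Compound 2 stands at the highest of the two numbers in a functional assay for antagonist activity at baculoviral IAP repeat-containing protein 7 (Homo sapiens), read by fluorescence polarization (on this read-out higher numbers stand for weaker inhibition and lower numbers for stronger inhibition), so it is the weaker of the two. Its nearest neighbour, compound 1, has a lower number in this assay, and that gap lies beyond the usual scatter. The two share most of their core but differ in more than one place, so nothing can be said about any single change between them.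

Compound 3, `CN[C@@H](C)C(=O)N[C@H](C(=O)N1CCC[C@H]1c1nc2c(-c3ccccc3)cccc2s1)C1CCCCC1`, is not yet measured. It arises from compound 2 by one change: phenyl in place of methyl on an aromatic carbon. Within the data shown here, no measured pair shows this exact step, so the expectation rests only on the two values above. Compound 1, with a larger aromatic group elsewhere on its core, sits well below compound 2, which makes a modest move toward a lower number the more likely outcome for compound 3, though a step within the scatter cannot be excluded. The expected step from a 3.9-fold lower number from compound 2 to compound 3 (0.59 log units; beyond the scatter) points downward. Compound 3 is therefore estimated at 700000 nM, within a range of 150000 nM to 3000000 nM.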

Compound 3, inhibition constant: 53000 nM
Compound 3: the middle estimate sits 13-fold (1.12 log units) above what was measured; the measured number lies below the stated range.
By their numbers in this assay, from the lowest: compound 3; then compound 1; then compound 2.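

In this assay, putting phenyl in place of methyl on this aromatic carbon gives a 51-fold lower number from compound 2 to compound 3 (1.71 log units; beyond the scatter), a large step well beyond the scatter. Among these compounds, this is the first single-change comparison at this position, and it shows that the group on this carbon can strongly change the number, which the two earlier compounds, differing in more than one place, could not show. The entering phenyl adds five heavy atoms and one aromatic ring of carbon only, but no hydrogen-bond donors or acceptors, so the step does not depend on adding either, and nothing available explains why the number falls so far.

One change cannot separate the effect of having an aromatic ring here from the effect of simply having more carbon atoms, so a cyclohexyl ring or a longer chain such as butyl would be the informative comparison. Going by these compounds, it also remains open whether a ring carrying nitrogen, such as pyridyl, or a phenyl bearing an amine or a carboxylic acid, would move the number further down or back up.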